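Swapping the pyrazine for a fluorophenyl at the carbonyl

A few compounds are considered here, and "the series" means these few. Any claim that something is new, unique, unknown or untested is made for them only; others in the source may bear on it.

Measured so far:
Compound 1 `Cc1cnc(C(=O)N2CCC3(CC2)CN(C(=O)Nc2ccc(OC(F)(F)F)cc2)CCO3)cn1`: 92 ug/mL
Compound 2 `O=C(Nc1ccc(OC(F)(F)F)cc1)N1CCOC2(CCN(C(=O)c3cc(Cl)ccn3)CC2)C1`: 89 ug/mL
Compound 3 `O=C(Nc1ccc(C(F)(F)F)cc1)N1CCOC2(CCN(C(=O)c3ccco3)CC2)C1`: 75 ug/mL

In an ADME assay for solubility, in simulated intestinal fluid (on this read-out lower numbers stand for lower solubility and higher numbers for higher solubility), compound 1 gives the highest of the three numbers, yet its gaps to compound 2 and to compound 3 both lie within the scatter, so the three values sit together. The unmeasured compound 4 `O=C(Nc1ccc(OC(F)(F)F)cc1)N1CCOC2(CCN(C(=O)c3ccccc3F)CC2)C1` differs from compound 1 in one place: 2-fluorophenyl in place of 5-methylpyrazin-2-yl on a carbonyl carbon. Within the data shown here, only one measured step touches the same carbonyl carbon, the change from a 1.0-fold lower number from compound 1 to compound 2 (0.01 log units; within the scatter), which kept a ring with two hetero atoms and moved the number not at all. Among the measured compounds shown here, no measured step exchanges such a ring for one of carbon only, so the data give no direct guide. Compound 3, which carries a different ring on that carbonyl, shows a value close to compound 1. The estimate for compound 4 in this assay is therefore a modest step down, a 2.0-fold lower number from compound 1 to compound 4 (0.31 log units; beyond the scatter), expected but uncertain. Compound 4 is estimated at 45 ug/mL, with a range from 18 ug/mL to 95 ug/mL.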

Compound 4, solubility: 62 ug/mL
Beside the measured number, compound 4's estimate is 1.4-fold (0.14 log units) below it; low and high end bracket the measured number.
By their numbers in this assay, from the lowest: compounds 4, 3, 2 and 1 (each within the scatter of the next).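

In this assay, the exchange at this carbonyl carbon of a six-membered aromatic ring with hetero atoms for one of carbon only gives a 1.5-fold lower number from compound 1 to compound 4 (0.17 log units; within the scatter). Starting from the 4-chloropyridin-2-yl group, the exchange for 2-fluorophenyl gives a 1.4-fold lower number from compound 2 to compound 4 (0.16 log units; within the scatter). Thus, at this position, going from the 2 hydrogen-bond acceptors of 5-methylpyrazin-2-yl to none in 2-fluorophenyl leaves the read-out within the scatter, though nothing at hand explains this result.

All four compounds shown carry an aromatic ring on this carbonyl carbon, so they leave open whether a group of another kind there, such as a saturated ring bearing an amine or a chain ending in a carboxylic acid, would move the number beyond the scatter. They also leave open how an unsubstituted phenyl would compare with 2-fluorophenyl.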